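The compounds below may be only part of what the source reports. "The series", "measured", "known", "first", "only" and "open" are said of these compounds alone.

Compound 2, `CN(C)C1(Cc2ccccc2)CCN(c2cc(C(F)(F)F)ccc2CNC(=O)Nc2cccc3c(=O)[nH]ccc23)CC1`, carries a urea whose aryl end is a bicyclic lactam, and in an assay on CHO cells for agonist activity at transient receptor potential cation channel subfamily V member 1 (Homo sapiens), read by scintillation counting, with a stated time of 5 min, in the presence of a further agent that is not named here (on this read-out lower numbers stand for an effect already at smaller amounts and higher numbers for an effect only at larger amounts of compound), compound 2 gives 43.7 nM. Within the data shown here, this is the only number in the set: the related compound 1, `CN(C)C1(Cc2ccccc2)CCN(c2cc(C(F)(F)F)ccc2CNC(=O)Nc2cccc3ccc(O)cc23)CC1`, in which the same position holds a ring bearing a hydroxyl group, is reported in this assay as "not active" (no number reported), with no value to compare. Among the measured compounds shown here, compound 2 therefore stands alone as the one compound with a measured concentration.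

Compound 3, `CN(C)C1(Cc2ccccc2)CCN(c2cc(C(F)(F)F)ccc2CNC(=O)Nc2cccc3ccncc23)CC1`, differs from compound 2 only at the urea nitrogen, where (a group of 10 heavy atoms (9 carbon, 1 nitrogen; one six-membered aromatic ring of carbon only, one six-membered aromatic ring with 1 hetero atom) in place of a group of 11 heavy atoms (9 carbon, 1 nitrogen, 1 oxygen; one six-membered aromatic ring of carbon only, one six-membered aromatic ring with 1 hetero atom), on an amide-type nitrogen), that is, a group of 10 heavy atoms (9 carbon, 1 nitrogen; one six-membered aromatic ring of carbon only, one six-membered aromatic ring with 1 hetero atom) in place of a group of 11 heavy atoms (9 carbon, 1 nitrogen, 1 oxygen; one six-membered aromatic ring of carbon only, one six-membered aromatic ring with 1 hetero atom). For the measured compounds named here, no step between two measured compounds informs this change. The account expects a step of a 6.9-fold higher number from compound 2 to compound 3 (0.84 log units; beyond the scatter) toward larger amounts, beyond the scatter, and estimates compound 3 at 300 nM, within 60 nM to 3000 nM.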

Compound 3, half-maximal effective concentration: "not active" (no number reported)
Compound 3: no number reported, so the estimate cannot be set against anything.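

In this assay compound 3 gives "not active" (no number reported) and so, with no number to set against compound 2, no new step can be read between the two. The compounds shown leave open how far compound 1 and compound 3 lie from compound 2 on this read-out. Nothing shown here offers an explanation for this result.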